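The compounds below may be only part of what the source reports. "The series", "measured", "known", "first", "only" and "open" are said of these compounds alone.

Of the compounds shown here, three from one series have been tested in a functional assay on SF-295 cells (Homo sapiens) for inhibition, read by sulforhodamine B assay, with a stated time of 48 h (on this read-out lower numbers stand for stronger inhibition and higher numbers for weaker inhibition), and a fourth awaits its number. Compound 1 `COc1cc(-c2nn(-c3cccc(NC(=O)Nc4cc(C(F)(F)F)cc(C(F)(F)F)c4)c3)cc2-c2ccncc2)ccc1Cl` gives 400 nM in this assay. Compound 2 `O=C(Nc1cccc(-n2cc(-c3ccncc3)c(-c3ccc(Cl)c(O)c3)n2)c1)Nc1cc(C(F)(F)F)cc(C(F)(F)F)c1` differs from it by a single change, (hydrogen in place of methyl on an oxygen on an aromatic ring), and gives 620 nM. That change produced a 1.6-fold higher number from compound 1 to compound 2 (0.19 log units; within the scatter), so the two numbers cannot be told apart with confidence.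

Compound 3 `COc1cc(-c2nn(-c3cccc(NC(=O)Nc4ccc(Cl)c(C(F)(F)F)c4)c3)cc2-c2ccncc2)ccc1Cl` carries a different outer portion; the difference between its core and that of compound 1 is not broken down here. In this assay compound 3 gives 840 nM. Its gap to compound 2 lies within the scatter, while its gap to compound 1 lies beyond it.

Compound 4 `O=C(Nc1cccc(-n2cc(-c3ccncc3)c(-c3ccc(Cl)c(O)c3)n2)c1)Nc1ccc(Cl)c(C(F)(F)F)c1` stands to compound 3 exactly as compound 2 stands to compound 1: the change is hydrogen in place of methyl on an oxygen on an aromatic ring, made at the same place with the same surroundings. Because the earlier instance gave a 1.6-fold higher number from compound 1 to compound 2 (0.19 log units; within the scatter), the expectation is that the step here will be of the same small size, a 1.5-fold higher number from compound 3 to compound 4 (0.19 log units; within the scatter), and will again stay within the scatter. On that basis compound 4 is estimated to give 1300 nM in this assay, with the true number expected to fall between 600 nM and 2800 nM. This estimate rests on a single earlier example, so a somewhat larger or smaller step would not be surprising.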

Compound 4, half-maximal inhibitory concentration: 740 nM
For compound 4 the middle estimate is 1.8-fold (0.24 log units) above the measured one, and the stated range covers the measured number.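

In this assay, swapping methoxy for hydroxy on the second core gives a small step (a 1.1-fold lower number from compound 3 to compound 4 (0.06 log units; within the scatter)), so here too the two numbers cannot be told apart with confidence. The two instances of this change do not differ by more than repeated measurements would be expected to: the same change on two cores in this assay, a 1.6-fold higher number (0.19 log units; within the scatter) from compound 1 to compound 2 and a 1.1-fold lower number (0.06 log units; within the scatter) from compound 3 to compound 4, 1.8-fold (0.25 log units) apart, within the scatter of two such steps. This shows that, on these two cores, the 4-chloro-3-methoxyphenyl to 4-chloro-3-hydroxyphenyl change carries over without a step that stands clear of the scatter, but it does not show that the change does nothing, since a small real shift could hide inside that scatter, and two pairs say nothing firm about any other core in the series.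

The compounds shown leave open what other groups at this place would do, for example an ethoxy group or a longer chain on the same oxygen, or an amine in place of the hydroxy group. They also leave open whether the same swap would stay this small on a core whose outer portion is more different from these two, or in a read-out other than this one on SF-295 cells.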